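The source may report more compounds than this note shows. Statements on the series, on what has been measured and on what is new or still open speak of the compounds shown alone.

The measured compounds:
Compound 1, `CCCCc1cn(C(c2ccccc2)c2cc3cc(Br)ccc3nc2OC)nn1`, gives -3.47%
Compound 2, `CCCc1cn(C(c2ccccc2)c2cc3cc(Br)ccc3nc2OC)nn1`, gives 0.85%
Compound 3, `COc1nc2ccc(Br)cc2cc1C(c1ccccc1)n1cc(CO)nn1`, gives 11.5%

All three numbers come from an ADME assay on HEK293 cells (Homo sapiens) for cytotoxicity, read by sulforhodamine B assay, with a stated time of 48 h, tested at 10 uM; on this read-out lower numbers stand for less inhibition and higher numbers for more inhibition at the one concentration tested (going by the name of the read-out). Compound 3 stands highest of the three: the nearest of the other two is separated from it by a number 10.7 percentage points higher from compound 2 to compound 3 (beyond the scatter), and the furthest by a number 15 percentage points higher from compound 1 to compound 3 (beyond the scatter). The two alkyl-bearing compounds are separated only by a number 4.3 percentage points higher from compound 1 to compound 2 (within the scatter).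

Compound 4 is `COc1nc2ccc(Br)cc2cc1C(c1ccccc1)n1cc(-c2cccc(F)c2)nn1`. It differs from compound 3 in one place: 3-fluorophenyl in place of hydroxymethyl on an aromatic carbon. The measured steps that bear on this are the two leading into compound 3, since they alter the same group that compound 4 alters: a number 15 percentage points higher from compound 1 to compound 3 (beyond the scatter) and a number 10.7 percentage points higher from compound 2 to compound 3 (beyond the scatter) each moved the number up modestly when a hydroxy replaced an alkyl chain. Among the compounds with values here, compound 4 removes the hydroxy again, yet what enters is an aromatic ring rather than an alkyl chain, and no measured step covers such an entry. The step of a number 6.5 percentage points lower from compound 3 to compound 4 (within the scatter) is therefore expected to be small, probably downward toward the alkyl-bearing compounds, with considerable uncertainty. Compound 4 is estimated to give 5% in this assay, within a range from -10% to 22%.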

Compound 4, a percentage reported as inhibition, at one concentration (the size of the read-out at that concentration, not a potency): 6.84%
The estimate for compound 4 lay 1.8 percentage points below the measured number; the range from low to high includes it.
By their numbers in this assay, from the lowest: compounds 1, 2, 4 and 3 (each within the scatter of the next, the first and the last beyond it).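

In this assay, a ring can sit at this position, on an aromatic carbon of the five-membered aromatic ring with 3 nitrogen, with no clear separation from the hydroxymethyl compound: the change to 3-fluorophenyl gives a number 4.7 percentage points lower from compound 3 to compound 4 (within the scatter) even though the entering group has no hydrogen-bond donor. Compared with the alkyl chains, the result is split: a number 6 percentage points higher from compound 2 to compound 4 (within the scatter) while a number 10.3 percentage points higher from compound 1 to compound 4 (beyond the scatter) so compound 4 is clearly separated only from the butyl compound, a separation that among the earlier compounds only the hydroxymethyl group had shown. No available evidence accounts for these differences or says what the cells respond to in this assay.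

The compounds shown leave open whether the fluorine contributes anything, since plain phenyl and the 2-fluorophenyl and 4-fluorophenyl groups do not appear among them. They also leave open how an aminomethyl group or a carboxylic acid at this same position would compare with hydroxymethyl and 3-fluorophenyl.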